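A few compounds are considered here, and "the series" means these few. Any claim that something is new, unique, unknown or untested is made for them only; others in the source may bear on it.

Compound 1 `O=c1cc(/C=C/c2ccc(O)cc2)oc2cc(O)ccc12` carries a single hydroxy group on its pendant ring; in a functional assay, in the presence of a further agent that is not named here (a lower number here means a stronger inhibitor, a higher number a weaker inhibitor), compound 1 gives 1650 nM. Compound 2 `O=c1cc(/C=C/c2ccc(O)c(O)c2)oc2cc(O)ccc12` differs from compound 1 by hydroxy in place of hydrogen on an aromatic carbon, and in this assay compound 2 gives 610 nM; the step of a 2.7-fold lower number from compound 1 to compound 2 (0.43 log units; beyond the scatter) is modest but beyond the scatter. Compound 3 `O=c1cc(/C=C/c2ccc(O)cc2)oc2cccc(O)c12` is built from the same atoms as compound 1 joined differently; how the two cores differ is not broken down here. In this assay compound 3 gives 980 nM, a number that lies within the scatter of both compound 1 and compound 2, so no order among the three can be claimed from it. Compound 4 `O=c1cc(/C=C/c2ccc(O)c(O)c2)oc2cccc(O)c12` is still to be measured; it differs from compound 3 by hydroxy in place of hydrogen on an aromatic carbon, the same change as from compound 1 to compound 2, at the same kind of place. The step of a 2.6-fold lower number from compound 3 to compound 4 (0.41 log units; beyond the scatter) is expected to be of similar size to the earlier step of a 2.7-fold lower number from compound 1 to compound 2 (0.43 log units; beyond the scatter). On that basis compound 4 is estimated at 380 nM in this assay, with a likely range from 150 nM to 900 nM.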

Compound 4, half-maximal inhibitory concentration: 510 nM
For compound 4 the middle estimate is 1.3-fold (0.13 log units) below the measured one; the range from low to high includes it.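

In this assay, hydroxy in place of hydrogen on an aromatic carbon gives a 1.9-fold lower number from compound 3 to compound 4 (0.28 log units; within the scatter), so on the core of compound 3 this step alone cannot be told apart from the ordinary spread of repeated measurements. Set beside the earlier step, the change reads alike on the two cores: the same change on two cores in this assay, a 2.7-fold lower number (0.43 log units; beyond the scatter) from compound 1 to compound 2 and a 1.9-fold lower number (0.28 log units; within the scatter) from compound 3 to compound 4, 1.4-fold (0.15 log units) apart, within the scatter of two such steps. Among these compounds, this shows that the two steps are compatible with a single effect carried from one core to the other, but it does not show that the step on the core of compound 3 is real, nor that the change would behave the same way on any further core, and only two pairs stand behind the comparison.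

The compounds shown leave open whether a methoxy group, a fluorine atom or an amine in the same place on the pendant ring would match hydroxy. They also leave open what a carboxylic acid there would do on either core.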